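The source may report more compounds than this note shows. Statements on the series, on what has been measured and on what is new or still open speak of the compounds shown alone.

Compound 1 `O=c1[nH]c2ccccc2cc1/C=N/O`, compound 2 `Cc1ccc2[nH]c(=O)c(/C=N/O)cc2c1` and compound 3 `Cc1ccc2[nH]c(=O)c(/C=N/Nc3ccccc3)cc2c1` have been measured in a functional assay, read by spectrophotometry, with a stated time of 30 min; a lower number here means a stronger inhibitor, a higher number a weaker inhibitor. Compound 1 gives 118000 nM, compound 2 gives 160000 nM, and compound 3 gives 62400 nM. The two cores differ in that (anilino in place of hydroxy on a double-bonded nitrogen), a change that gave a 2.6-fold lower number from compound 2 to compound 3 (0.41 log units; beyond the scatter). Compound 1 differs from compound 2 in that (hydrogen in place of methyl on an aromatic carbon), and that gave a 1.4-fold lower number from compound 2 to compound 1 (0.13 log units; within the scatter). Compound 4 `O=c1[nH]c2ccccc2cc1/C=N/Nc1ccccc1` has not yet been measured; it differs from compound 3 in that (hydrogen in place of methyl on an aromatic carbon), the same change as from compound 2 to compound 1. Because the earlier step was a 1.4-fold lower number from compound 2 to compound 1 (0.13 log units; within the scatter), a similarly small step a 1.2-fold lower number from compound 3 to compound 4 (0.10 log units; within the scatter) is expected here. Compound 4 is therefore estimated at 50000 nM in this assay, most likely between 20000 nM and 130000 nM.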

Compound 4, half-maximal inhibitory concentration: 76500 nM
The estimate for compound 4 lay 1.5-fold (0.18 log units) below the measured number; measured number inside the range.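

In this assay, hydrogen in place of methyl on an aromatic carbon gave a 1.2-fold higher number from compound 3 to compound 4 (0.09 log units; within the scatter). Set beside the same change on the other core, the two steps do not differ: the same change on two cores in this assay, a 1.4-fold lower number (0.13 log units; within the scatter) from compound 2 to compound 1 and a 1.2-fold higher number (0.09 log units; within the scatter) from compound 3 to compound 4, 1.7-fold (0.22 log units) apart, within the scatter of two such steps. Among these compounds, this shows that, on these two cores, the change leaves the number within the scatter, but with only two pairs, it gives the step no reliable direction and does not show that the result would hold on any other core.

The compounds shown leave open what a methoxy group, a chlorine atom or a carboxylic acid would do on the same aromatic carbon. They also leave open how an amine or a longer chain would fare there.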